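A few compounds are considered here, and "the series" means these few. Any claim that something is new, unique, unknown or untested is made for them only; others in the source may bear on it.

Of the compounds shown here, two have been read in a functional assay on HL-60 cells (Homo sapiens) for cytotoxicity, read by MTT assay, with a stated time of 48 h; a lower number here means a stronger inhibitor, a higher number a weaker inhibitor. There compound 1 `O=C(N[C@H]1CC[C@]2(CC1)OC[C@]1(O2)C2CC3CC(C2)CC1C3)c1ccc(O)c(O)c1` gives 35500 nM. Compound 2 `O=C(NO)[C@H]1CC[C@@]2(CC1)OC[C@]1(OO2)C2CC3CC(C2)CC1C3` gives > 50000 nM, which is a limit of the assay and not a number. That places compound 2 at the limit of > 50000 nM in this assay, at which 1 of the 2 values shown sits.

The change under consideration leads to compound 3 `O=C(O)[C@H]1CC[C@@]2(CC1)OC[C@]1(OO2)C2CC3CC(C2)CC1C3`: hydroxy in place of hydroxyamino on a carbonyl carbon. In words, this is hydroxy in place of hydroxyamino on a carbonyl carbon, or hydroxycarbamoyl to carboxy. Among the measured compounds shown here, no measured step covers this change, so the expectation rests on the structural change and on the two readings alone. For the measured compounds named here, the only numerical reading, compound 1 at 35500 nM, gives no sign of strong inhibition, and this supports an expectation of weak inhibition for compound 3. The estimated step of a number no higher from compound 2 to compound 3 (the limit leaves the size open) is expected to stay within the scatter of this assay, with neither direction favoured. A result that again returns only a limit is expected to be the likelier outcome. For compound 3 the estimate is 50000 nM, with an expected range of 20000 nM to 100000 nM.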

Compound 3, half-maximal inhibitory concentration: > 100000 nM
Compound 3: only a limit was reported; the forecaster's own chance of this, stated with the estimate: 65%; middle value at least 2.0-fold (0.30 log units) from the limit.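

Among the compounds shown here, compound 2 and compound 3 both stand only as limits of the assay in this assay, and no step between them can be read. The compounds shown leave open where either one truly lies past its limit, and whether hydroxycarbamoyl or carboxy on the shared core gives the stronger inhibitor in this assay.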